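The source may report more compounds than this note shows. Statements on the series, on what has been measured and on what is new or still open speak of the compounds shown alone.

Measured so far in a functional assay on 786-0 cells (Homo sapiens) for cytotoxicity, read by sulforhodamine B assay, with a stated time of 48 h; a higher number here means a weaker inhibitor of growth, a lower number a stronger inhibitor of growth:
- compound 1 `ClCc1ccc(Cn2cnc3c(Cl)ncnc32)cc1` gives 1020 nM
- compound 2 `ClCc1cccc(Cn2cnc3ncnc(Cl)c32)c1` gives 2040 nM
- compound 3 `ClCc1ccccc1Cn1cnc2ncnc(Cl)c21` gives 3980 nM

Compound 3 holds the highest number of the three. Its nearest neighbour is compound 2, whose number is lower by a gap that stays within the usual scatter, so these two values do not separate compound 3 from compound 2. Compound 1 stands furthest away, with a number lower than that of compound 3 by a gap beyond the scatter, so compound 1 is the stronger growth inhibitor of that pair.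

Compound 4 `ClCc1ccccc1Cn1cnc2nc(Cl)nc(Cl)c21` is the next compound in the series and is not yet measured. Relative to compound 3 the change is chloro in place of hydrogen on an aromatic carbon. Among the measured compounds shown here, none of the measured pairs differs in this one place, so no measured step speaks directly to what this addition does here. The expectation is that the step from compound 3 to compound 4 in this assay will be small, a 1.1-fold lower number from compound 3 to compound 4 (0.06 log units; within the scatter), with no change beyond the scatter in either direction. On that basis compound 4 is estimated at 3500 nM, within a range from 1200 nM to 10000 nM.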

Compound 4, concentration for 50% growth inhibition: 2630 nM
Estimate against measurement, compound 4: 1.3-fold (0.12 log units) above; the measured number falls inside the stated range.
By their numbers in this assay, from the lowest: compounds 1, 2, 4 and 3 (each within the scatter of the next, the first and the last beyond it).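

In this assay, chloro in place of hydrogen on the aromatic carbon between two ring nitrogen atoms gives a 1.5-fold lower number from compound 3 to compound 4 (0.18 log units; within the scatter). Among the compounds shown here, this is the first step that changes a single place, and it shows that this carbon can carry a chloro group with no change beyond the scatter, at least with the rest of compound 3 held constant. No measurement at hand explains this outcome or bears on what the added chloro group does at this position.

The compounds shown leave open whether the same chloro step would also stay within the scatter on the background of compound 1 or compound 2, so this one step cannot yet be treated as a rule for the series. They also leave open whether this carbon would accept a different kind of group, such as an amine, a methoxy group or a longer chain, as it accepts chloro here.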